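From methoxycarbonyl to propoxycarbonyl on compound 1

The compounds below may be only part of what the source reports. "The series", "measured", "known", "first", "only" and "open" are said of these compounds alone.

Measured in a functional assay on the whole organism for inhibition, with Rattus norvegicus as the target, read by paw edema, with stated times of 1 h and 3 h; on this read-out lower numbers stand for an effect already at smaller amounts and higher numbers for an effect only at larger amounts of compound:
compound 1 `COC(=O)CO/N=C(\C)c1ccc(Cl)cc1`: 24 mg/kg
compound 2 `COC(=O)CO/N=C(\C)c1ccc(Br)cc1`: 14 mg/kg
compound 3 `C/C(=N\OC(C)C(=O)O)c1ccc(Cl)cc1`: 55 mg/kg

Among these three, compound 1 lies within the scatter of compound 2, while compound 3 gives a higher number. Compound 4 `CCCOC(=O)CO/N=C(\C)c1ccc(Cl)cc1` has not yet been measured in this assay. It differs from compound 1 in one place: ethyl in place of hydrogen on a saturated chain carbon bound to an oxygen next to a carbonyl group, which turns methoxycarbonyl into propoxycarbonyl.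

Neither measured step makes this change. Bromo in place of chloro on an aromatic carbon gave a 1.7-fold lower number from compound 1 to compound 2 (0.23 log units; within the scatter) and says little about the new chain. The closer precedent is 1-carboxyethyl in place of (methoxycarbonyl)methyl on an oxygen, which gave a 2.3-fold higher number from compound 1 to compound 3 (0.36 log units; beyond the scatter), but that step replaces the methoxycarbonyl group altogether. Within the data shown here, with only this modest step as a guide, no change beyond the scatter is expected in either direction, and the estimated step is a 1.0-fold higher number from compound 1 to compound 4 (0.02 log units; within the scatter). For compound 4 the estimated value is 25 mg/kg, with an expected range of 11 mg/kg to 55 mg/kg.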

Compound 4, dose for half-maximal effect: 14 mg/kg
The estimate for compound 4 lay 1.8-fold (0.25 log units) above the measured number, within the range that was stated.
By their numbers in this assay, from the lowest: compounds 2, 4 and 1 (each within the scatter of the next); then compound 3.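

In this assay, the change from methoxycarbonyl to propoxycarbonyl on compound 1 gives a 1.7-fold lower number from compound 1 to compound 4 (0.23 log units; within the scatter). This is the first step shown that keeps the carbonyl group and alters only the chain on its oxygen, and it shows that methoxy can give way to propoxy without a step beyond the scatter. That differs from the replacement of the whole group by 1-carboxyethyl, which gives a 2.3-fold higher number from compound 1 to compound 3 (0.36 log units; beyond the scatter), though no data shown explain the result for the propoxy chain.

The compounds shown leave open whether a longer chain such as hexyl, a branched chain such as isopropyl, a benzyl group or an amine in place of propoxy would stay within the scatter of compound 1. They also leave open how propoxycarbonyl reads out with bromo in place of chloro on the aromatic carbon.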